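From a Dimethoxyethyl Amide to a Carboxymethyl Amide

The source may hold more compounds than are shown below. What is called first, only, known or untested is meant among the compounds shown, and "the series" means these compounds.

Compound 1 `CCn1c(C(=O)NCCN(C)C)ccc1C(CC)(CC)c1ccc(OCC(=O)C(C)(C)C)c(C)c1`: 2300 nM
Compound 2 `CCn1c(C(=O)NCC(OC)OC)ccc1C(CC)(CC)c1ccc(OCC(O)C(C)(C)C)c(C)c1`: 23200 nM
Compound 3 `CC[C@@H](C)[C@H](NC(=O)c1ccc(C(CC)(CC)c2ccc(OCC(=O)C(C)(C)C)c(C)c2)n1CC)C(=O)O`: 247 nM

In a functional assay on HepG2 cells (Homo sapiens), read by MTT assay, with a stated time of 48 h (a lower number here means a stronger inhibitor, a higher number a weaker inhibitor), compound 2 is the weakest inhibitor of the three, at 23200 nM. Compound 4 `CCn1c(C(=O)N(C)CC(=O)O)ccc1C(CC)(CC)c1ccc(OCC(O)C(C)(C)C)c(C)c1` differs from it in one place: (carboxymethyl)(methyl)amino in place of (2,2-dimethoxyethyl)amino on a carbonyl carbon. In words, (carboxymethyl)(methyl)amino stands in place of (2,2-dimethoxyethyl)amino on a carbonyl carbon. For the measured compounds named here, one measured step bears on this change. Putting 1-carboxy-2-methylbutyl in place of 2-(dimethylamino)ethyl on an amide-type nitrogen gave a 9.3-fold lower number from compound 1 to compound 3 (0.97 log units; beyond the scatter). That step began from a different group, and compound 1 also differs from compound 2 elsewhere, so it is only a rough guide. A lower number is expected in this assay, probably by a smaller step. The estimated change is a 4.6-fold lower number from compound 2 to compound 4 (0.67 log units; beyond the scatter). For compound 4 the estimated value is 5000 nM, with an expected range of 1200 nM to 20000 nM.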

Compound 4, half-maximal inhibitory concentration: 17100 nM
For compound 4 the middle estimate is 3.4-fold (0.53 log units) below the measured one; low and high end bracket the measured number.
By their numbers in this assay, from the lowest: compound 3; then compound 1; then compounds 4 and 2 (each within the scatter of the next).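

In this assay, (carboxymethyl)(methyl)amino in place of (2,2-dimethoxyethyl)amino gives a 1.4-fold lower number from compound 2 to compound 4 (0.13 log units; within the scatter), so this change on the carbonyl carbon makes no clear difference. A carboxylic acid in this part of the molecule therefore does not by itself bring the gain seen with 1-carboxy-2-methylbutyl, which gave a 9.3-fold lower number from compound 1 to compound 3 (0.97 log units; beyond the scatter). No measurement shown explains this contrast.

As far as these compounds go, it remains open whether 1-carboxy-2-methylbutyl would give a lower number on the core of compound 2. A longer chain such as 2-carboxyethyl, or carboxymethyl without the methyl on the nitrogen, is also untested among the compounds shown.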